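Replacing the hydroxy group of compound 3 with hydrogen

A few compounds are considered here, and "the series" means these few. Any claim that something is new, unique, unknown or untested is made for them only; others in the source may bear on it.

Of the compounds shown here, three have been tested so far, and none has yet given a number. In a functional assay on L1210 cells (Mus musculus) for antiproliferative activity (a lower number here means a stronger inhibitor, a higher number a weaker inhibitor), compound 1 `COc1ccc(O)c2c(=O)ccn(C)c12` gives > 40000 nM, which is a limit of the assay. Compound 2 `COc1cc2nccc(O)c2c(O)c1OC` gives > 40000 nM, also a limit. Compound 3 `COc1cc2c(c(O)c1OC)c(=O)ccn2C` gives > 40000 nM, again a limit. Compound 3 therefore cannot be ranked against the other two, and the whole set stands at the limit of > 40000 nM in this assay, at which 3 of the 3 values shown sit.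

The next compound is compound 4 `COc1cc2c(=O)ccn(C)c2cc1OC`. It carries hydrogen in place of hydroxy on an aromatic carbon of compound 3, at a place ortho to a methoxy group and ortho to a fused ring (hydrogen in place of hydroxy on an aromatic carbon). Going by the values given here, no measured pair shows this change on its own, so its size can only be judged indirectly. No step beyond the scatter is expected in this assay, in either direction, since compound 3 shares the limit of > 40000 nM in this assay, at which 3 of the 3 values shown sit, with the other two compounds. The estimated change is a number no higher from compound 3 to compound 4 (the limit leaves the size open). Compound 4 may well be reported as a limit too. For compound 4 the expected value is 40000 nM, with an estimated range of 20000 nM to 80000 nM.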

Compound 4, half-maximal inhibitory concentration: > 40000 nM
Compound 4 was reported as a limit (the forecaster's own chance of this, stated with the estimate: 75%); the middle value lies on the limit itself.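

Compound 3 and compound 4 both stand at a limit, so the step between them cannot be read: the limit of > 40000 nM in this assay, at which 4 of the 4 values shown sit. The compounds shown leave open how hydroxy and hydrogen compare at this place on the shared core, and which change, if any, would bring a value off the limit in this assay.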